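This account rests on a few compounds, and the source may have more. Where it says the series, first, only, none or still open, it means among the compounds named here.

Measured compounds:
Compound 1, `CCCCOc1ccc(C(=O)N/N=C/c2ccc3c(c2)no[n+]3[O-])cc1`: in an ADME assay on cells (Fibroblast, Homo sapiens) for inhibition, read by MTT assay, with a stated time of 24 h (a lower number here means a stronger inhibitor, a higher number a weaker inhibitor), compound 1 gives only a limit, > 200000 nM.
Compound 2, `NS(=O)(=O)c1ccc(C(=O)N/N=C/c2ccc3c(c2)no[n+]3[O-])cc1`: in this assay compound 2 gives 60000 nM.
Compound 3, `O=C(N/N=C/c1ccc2c(c1)no[n+]2[O-])c1ccc(Cl)cc1Cl`: in this assay compound 3 gives 38300 nM.

Among the two numbers reported, compound 2 sits at the higher end, and its nearest neighbour, compound 3, lies within the scatter of it, so the two cannot be ordered. The third value is a limit (the limit of > 200000 nM in this assay, at which 1 of the 3 values shown sits), not a number.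

The account now follows the step from compound 2 to compound 4, `CCCc1ccc(C(=O)N/N=C/c2ccc3c(c2)no[n+]3[O-])cc1`, which has not yet been measured in this assay. The change is propyl in place of sulfamoyl on an aromatic carbon. For the measured compounds named here, one measured step bears on it: an at least 3.3-fold lower number from compound 1 to compound 2 (0.52 log units; beyond the scatter). Compound 4, like compound 1, carries a carbon chain where compound 2 carries the sulfamoyl group, so the change runs back in the direction of compound 1. A step toward higher numbers, of at least the size seen there, is therefore expected for compound 4, with a real chance that only a limit is recorded.

Compound 4 is expected to give 150000 nM, within 50000 nM to 400000 nM, which means a 2.5-fold higher number from compound 2 to compound 4 (0.40 log units; beyond the scatter).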

Compound 4, half-maximal inhibitory concentration: > 200000 nM
Compound 4 ended at the assay's limit; the forecaster's own chance of this, stated with the estimate: 40%; at least 1.3-fold (0.12 log units) between middle value and limit.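

In this assay, exchanging sulfamoyl for propyl on the aromatic carbon para to a large group gives an at least 3.3-fold higher number from compound 2 to compound 4 (0.52 log units; beyond the scatter). Until now only butoxy could be set against sulfamoyl at this position, and a propyl chain, with no oxygen and no hydrogen-bond donors or acceptors, now gives the same kind of result, so the readable number of compound 2 stands apart from two different groups rather than one; compound 3, which carries neither sulfamoyl nor a carbon chain at this position, also gives a readable number, 38300 nM, so a readable number does not depend on sulfamoyl across all the compounds shown. The step between compound 1 and compound 4 cannot be read, because neither gives a number, only a limit: the limit of > 200000 nM in this assay, at which 2 of the 4 values shown sit.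

The compounds shown leave open how far compound 1 and compound 4 lie beyond that limit, and so whether butoxy and propyl differ at all. They also leave open whether an amine or a carboxylic acid at this position would give a readable number, as sulfamoyl does, or only a limit, as propyl does.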